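Working notes: isopropyl-to-hydrogen step in the sulfonamide series

The source may hold more compounds than are shown below. What is called first, only, known or untested is meant among the compounds shown, and "the series" means these compounds.

Measured so far in a functional assay on RS4-11 cells (Homo sapiens) for inhibition, read by CCK-8 assay, with a stated time of 48 h; a lower number here means a stronger inhibitor, a higher number a weaker inhibitor:
compound 1 `O=C(NCCNS(=O)(=O)c1sccc1-c1ccccc1Oc1ccc(O)c(O)c1)Nc1cc(Cl)cc(Cl)c1` gives 6200 nM.
compound 2 `CC(C)c1ccc(Oc2ccc(O)c(O)c2)c(-c2ccsc2S(=O)(=O)NCCNC(=O)Nc2cc(Cl)cc(Cl)c2)c1` gives 6400 nM.
compound 3 `CC(C)c1ccc(Oc2ccc(O)c(O)c2)c(-c2ccsc2S(=O)(=O)NCCNC(=S)Nc2cc(C(F)(F)F)cc(C(F)(F)F)c2)c1` gives 3700 nM.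

Compound 1 and compound 2 share one core; compound 3 is built on another, and the difference between the two cores is not broken down here. Compound 3 shows the lowest number of the three, but its gaps to compound 1 and compound 2 lie within the scatter, so no order is claimed.

Within the first core, the change hydrogen in place of isopropyl on an aromatic carbon gave a 1.0-fold lower number from compound 2 to compound 1 (0.01 log units; within the scatter), a flat step.

Compound 4 `O=S(=O)(NCCNC(=S)Nc1cc(C(F)(F)F)cc(C(F)(F)F)c1)c1sccc1-c1ccccc1Oc1ccc(O)c(O)c1`, not yet measured, carries the same change on the core of compound 3: hydrogen in place of isopropyl on an aromatic carbon. Since compound 2 to compound 1 gave a 1.0-fold lower number from compound 2 to compound 1 (0.01 log units; within the scatter), the step of a 1.0-fold higher number from compound 3 to compound 4 (0.01 log units; within the scatter) is expected to be equally flat in this assay. Compound 4 is therefore estimated at 3800 nM, with a range of 1900 nM to 7600 nM.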

Compound 4, half-maximal inhibitory concentration: 4800 nM
The estimate for compound 4 lay 1.3-fold (0.10 log units) below the measured number; measured number inside the range.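

Hydrogen in place of isopropyl gave a 1.3-fold higher number from compound 3 to compound 4 (0.11 log units; within the scatter) in this assay. Set beside the earlier step, the change carries across the two cores without a difference that can be read: the same change on two cores in this assay, a 1.0-fold lower number (0.01 log units; within the scatter) from compound 2 to compound 1 and a 1.3-fold higher number (0.11 log units; within the scatter) from compound 3 to compound 4, 1.3-fold (0.13 log units) apart, within the scatter of two such steps. For the compounds shown here, this shows only that the step stays flat on these two cores; it does not show that the same would hold on any other core, nor does it give a rule for the series as a whole.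

The compounds shown leave open whether a group other than hydrogen or isopropyl on this aromatic carbon, such as a methoxy group, an amine or a carboxylic acid, would shift the number. They also leave open whether a longer alkyl chain there would stay equally flat.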